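Extending an Ethoxy Chain to Butoxy

This account rests on a few compounds, and the source may have more. Where it says the series, first, only, none or still open, it means among the compounds named here.

Measured compounds:
compound 1 `CCOC1=CC(=O)c2ccccc2C1=O` with 23800 nM
compound 2 `COc1ccc2c(c1)C(=O)C=CC2=O` with 22700 nM
compound 3 `C=CCOc1ccc2c(c1)C(=O)C=CC2=O` with 27200 nM

All three numbers come from a functional assay on HeLa cells (Homo sapiens) for cytotoxicity; on this read-out higher numbers stand for weaker inhibition and lower numbers for stronger inhibition. Compound 1 sits within the scatter of both neighbours: its number differs from that of compound 2 and from that of compound 3 by less than the usual spread of repeated measurements, so the three compounds cannot be told apart on this read-out.

The compound to be measured is compound 4 `CCCCOC1=CC(=O)c2ccccc2C1=O`, which differs from compound 1 in one place: ethyl in place of hydrogen on a saturated chain carbon, two bonds along the chain from an oxygen on an unsaturated carbon. Put another way, the ethoxy group of compound 1 becomes a butoxy group.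

One measured step speaks to a change of this kind, a lengthening of the chain carried by an oxygen on an aromatic ring: a 1.2-fold higher number from compound 2 to compound 3 (0.08 log units; within the scatter). That step did not move the number beyond the scatter. With only this single, flat step to go on, the expectation for the move from compound 1 to compound 4 in this assay is no change beyond the scatter, and the step expected is a 1.0-fold higher number from compound 1 to compound 4 (0.00 log units; within the scatter).

Compound 4 is therefore estimated at 24000 nM, with a range from 12000 nM to 48000 nM.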

Compound 4, half-maximal inhibitory concentration: 35300 nM
Estimate against measurement, compound 4: 1.5-fold (0.17 log units) below; the measured number falls inside the stated range.
By their numbers in this assay, from the lowest: compounds 2, 1, 3 and 4 (each within the scatter of the next).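

On the core of compound 1, the change from ethoxy to butoxy places ethyl on a saturated chain carbon, two bonds along the chain from an oxygen on an unsaturated carbon. In this assay this change gives a 1.5-fold higher number from compound 1 to compound 4 (0.17 log units; within the scatter) and so stays within the usual scatter of repeated measurements. Within the data shown here, the only earlier step, a 1.2-fold higher number from compound 2 to compound 3 (0.08 log units; within the scatter), concerned a different core and a chain on an oxygen on an aromatic ring, whereas this result tests the chain on the core of compound 1 directly and shows that this position accepts the ethyl group with no change that can be told from the scatter. Nothing available here explains this result or bears on what lies behind it.

The compounds shown leave open whether a longer chain, such as octyloxy, would move the number beyond the scatter on this core. From the compounds shown here alone, it also remains open whether an amine or a carboxylic acid at the end of the butoxy chain would do so.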